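Quinone carbamate series: branched chain replaces ethoxy side arm

A few compounds are considered here, and "the series" means these few. Any claim that something is new, unique, unknown or untested is made for them only; others in the source may bear on it.

Working notes on three measured compounds and one open position. The series rests on a shared core carrying two aziridine groups, as in compound 1 `CC1=C(N2CC2)C(=O)C(CCCOC(N)=O)=C(N2CC2)C1=O`, compound 2 `CCOC(COC(N)=O)C1=C(N2CC2)C(=O)C(C)=C(N2CC2)C1=O` and compound 3 `CCCC1=C(N2CC2)C(=O)C(CCC)=C(N2CC2)C1=O`. Potency is read in a functional assay on L1210 cells (Mus musculus), with a stated time of 1 days; a lower number here means a less potent compound, a higher number a more potent compound, by a factor of ten per unit of this negative logarithm. In this assay compound 1 gives 5.48, compound 2 gives 4.62 and compound 3 gives 4.14. Compound 2 thus stands second highest of the three numbers: its nearest neighbour is compound 3, which lies lower by a gap beyond the usual scatter, and the furthest is compound 1, which lies higher, again beyond the scatter.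

The open position is compound 4 `CC1=C(N2CC2)C(=O)C(C(C)COC(N)=O)=C(N2CC2)C1=O`. It differs from compound 2 in one place: methyl in place of ethoxy on a saturated chain carbon bound to a double-bonded ring carbon and a saturated chain carbon. The carbamate end of the chain is kept in both.

For the measured compounds named here, no single-change pair among the measured compounds covers this replacement, so the step must be judged from the whole set. An upward step from compound 2 to compound 4, larger than the scatter, is expected, because compound 1 gives 5.48 while also carrying a methyl on the core and a carbamate-terminated chain. The step is estimated at a number 0.58 log units higher from compound 2 to compound 4 (beyond the scatter). Compound 4 is therefore expected at 5.2, with a plausible range from 4.5 to 5.9.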

Compound 4, logarithm of the reciprocal of the active concentration, log(1/C): 5.31
The estimate for compound 4 lay 0.11 log units below the measured number; the range from low to high includes it.
By their numbers in this assay, from the lowest: compound 3; then compound 2; then compounds 4 and 1 (each within the scatter of the next).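

In this assay, this position now has its first single-change reading, a number 0.69 log units higher from compound 2 to compound 4 (beyond the scatter), so methyl in place of ethoxy on a saturated chain carbon bound to a double-bonded ring carbon and a saturated chain carbon goes with a higher number while the carbamate end stays the same. The second reading, a number 0.17 log units lower from compound 1 to compound 4 (within the scatter), shows that the two carbamate-ended groups of 7 heavy atoms on a double-bonded ring carbon cannot be told apart in this assay, so the chain carrying the methyl and the chain of compound 1 stand level here. No measurement on hand bears on why the exchange of ethoxy for methyl reads this way.

The compounds shown do not tell whether the step belongs to methyl itself or to the absence of ethoxy, and a hydroxyl, an ethyl or a propoxy group on that same saturated chain carbon would help to separate the two. They also leave open whether the carbamate end is needed on the chain of compound 4, which a primary amine or a carboxylic acid at that end would test.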